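The source may report more compounds than this note shows. Statements on the series, on what has been measured and on what is new or still open speak of the compounds shown alone.

Three compounds have been measured so far in a physicochemical assay for solubility, in phosphate buffer, measured as kinetic solubility, with a stated time of 1 h, at pH 7.4; on this read-out lower numbers stand for lower solubility and higher numbers for higher solubility:

Compound 1 `Cc1cc(C)cc(NC(=O)COc2cc(C)nc3ccc(Cl)cc23)c1` gives 8000 nM.
Compound 2 `COc1ccc2nc(C)cc(OC(C)C(=O)Nc3cc(C)cc(C)c3)c2c1` gives 61000 nM.
Compound 3 `COc1cccc(NC(=O)COc2cc(C)nc3ccc(OC)cc23)c1` gives 35000 nM.

Among these three numbers compound 3 stands second highest. Its nearest neighbour is compound 2, whose number lies within the usual scatter of it, so no order between the two can be claimed; the furthest is compound 1, whose lower number lies beyond the scatter.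

Compound 4 `COc1ccc2nc(C)cc(OCC(=O)NNC(=O)c3ccncc3)c2c1` has not yet been measured in this assay. It differs from compound 3 in a single place: ((pyridin-4-yl)carbonyl)amino in place of 3-methoxyphenyl on an amide-type nitrogen. Among the compounds with values here, no step between two measured compounds shows a change of this kind, so any expectation rests on the structural change alone and carries considerable uncertainty. The author expects a rise in solubility from compound 3 to compound 4, moderate in size and probably just beyond the scatter: a 2.6-fold higher number from compound 3 to compound 4 (0.41 log units; beyond the scatter). For compound 4 in this assay the estimated value is 90000 nM, with a range from 35000 nM to 250000 nM.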

Compound 4, solubility: >= 375000 nM
Compound 4 gave a limit, no number; the forecaster's own chance of this, stated with the estimate: 5%; at least 4.1-fold (0.61 log units) between middle value and limit.
By their numbers in this assay, from the lowest: compound 1; then compounds 3 and 2 (each within the scatter of the next). At a limit, above all of these: compound 4.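

In this assay, ((pyridin-4-yl)carbonyl)amino in place of 3-methoxyphenyl on an amide-type nitrogen gives an at least 10-fold higher number from compound 3 to compound 4 (1.02 log units; beyond the scatter), the only step shown at this place and one that earlier compounds could not provide. Compound 4 gives >= 375000 nM, which is a limit of the assay and not a number. The full size of the step stays unknown because the reading for compound 4 is a limit: the limit of >= 375000 nM in this assay, at which 1 of the 4 values shown sits.

The compounds shown do not separate the contribution of the pyridine ring from that of the carbonyl and amino link that enter with it. They also leave open how a benzoylamino group, with its ring of carbon only, or a pyridin-4-yl group without the link would read at this place in this assay.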